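The source may hold more compounds than are shown below. What is called first, only, known or untested is meant among the compounds shown, and "the series" means these compounds.

Measured compounds:
compound 1 `O=C1C(N2CCCCC2)=CC(=O)c2c1nc1n2[C@H]2OC[C@@H](O)[C@H]2OC1`
compound 2 `O=C1C=C(Nc2cccc(Cl)c2)C(=O)c2c1nc1n2[C@H]2OC[C@@H](O)[C@H]2OC1`
compound 3 `O=C1C=C(Nc2ccc(Br)cc2)C(=O)c2c1nc1n2[C@H]2OC[C@@H](O)[C@H]2OC1`

In a functional assay on ECa-109 cells for inhibition, with ECa-109 cell line (Homo sapiens) as the target, read by sulforhodamine B assay (on this read-out higher numbers stand for weaker inhibition and lower numbers for stronger inhibition), compound 1 gives > 8000 nM, which is a limit of the assay rather than a number (the limit of > 8000 nM in this assay, at which 1 of the 3 values shown sits). Compound 2 gives 4690 nM and compound 3 gives 2850 nM, so compound 1 stands at the weak end of what has been measured. Compound 4 `O=C1C(Nc2ccc(I)cc2)=CC(=O)c2c1nc1n2[C@H]2OC[C@@H](O)[C@H]2OC1` carries (4-iodophenyl)amino in place of piperidin-1-yl on a double-bonded ring carbon. Within the data shown here, no measured step covers this exchange directly; the only step that bears on it, a 1.6-fold lower number from compound 2 to compound 3 (0.22 log units; within the scatter), trades one halogen-bearing phenylamino group for another and stays within the scatter. Since compound 3 gives 2850 nM, compound 4 is expected at about 2700 nM, ranging from 1000 nM to 7500 nM. This expected move, an at least 2.9-fold lower number from compound 1 to compound 4 (0.47 log units; beyond the scatter), would carry compound 4 from a limit into a measurable number.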

Compound 4, half-maximal inhibitory concentration: 2530 nM
For compound 4 the middle estimate is 1.1-fold (0.03 log units) above the measured one; measured number inside the range.
By their numbers in this assay, from the lowest: compounds 4, 3 and 2 (each within the scatter of the next). At a limit, above all of these: compound 1.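

On a double-bonded ring carbon, in this assay, putting (4-iodophenyl)amino in place of piperidin-1-yl gives an at least 3.1-fold lower number from compound 1 to compound 4 (0.49 log units; beyond the scatter). The earlier step only traded one halogen-bearing phenylamino group for another and stayed within the scatter, whereas this exchange replaces a non-aromatic ring with an aromatic one and goes beyond it. Compound 1 gives > 8000 nM, which is a limit of the assay and not a number, so the true size of this step stays unknown: the limit of > 8000 nM in this assay, at which 1 of the 4 values shown sits.

The compounds shown leave open whether the aromatic ring, the amine hydrogen or the iodine accounts for the change. A plain phenylamino group or a benzylamino group at this place would help to separate these features.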